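Dropping the Bromine from Compound 1

This account rests on a few compounds, and the source may have more. Where it says the series, first, only, none or still open, it means among the compounds named here.

Measured in a functional assay on NCI-H460 cells (Homo sapiens) for inhibition, read by MTT assay, with a stated time of 72 h; on this read-out higher numbers stand for weaker inhibition and lower numbers for stronger inhibition:
compound 1 `CCN(CC)CCCn1c(=O)c(=Cc2ccccc2O)s/c1=C1\C(=O)Nc2ccc(Br)cc21` gives 51700 nM
compound 2 `CN(C)CCn1c(=O)c(=Cc2ccc(F)cc2F)s/c1=C1\C(=O)Nc2cc(F)ccc21` gives 3200 nM
compound 3 `CCN(CC)CCCn1c(=O)c(=Cc2ccc(F)c(F)c2)s/c1=C1\C(=O)Nc2ccc(F)cc21` gives 1300 nM

Compound 1 shows the highest number of the three, with compound 2 and compound 3 both well beyond the scatter below it. Compound 4 `CCN(CC)CCCn1c(=O)c(=Cc2ccccc2O)s/c1=C1\C(=O)Nc2ccccc21` differs from compound 1 in one place: hydrogen in place of bromo on an aromatic carbon. Among the measured compounds shown here, no pair of measured compounds differs by this single change alone; compound 2 and compound 3 differ from compound 1 in several places at once, so their values give no direct guide. The step from compound 1 to compound 4 is therefore expected to be small, a 1.1-fold higher number from compound 1 to compound 4 (0.03 log units; within the scatter), and not clearly beyond the scatter in either direction. Compound 4 is estimated at 55000 nM in this assay, within a range from 15000 nM to 160000 nM.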

Compound 4, half-maximal inhibitory concentration: > 200000 nM
Compound 4 was reported as a limit (the forecaster's own chance of this, stated with the estimate: 15%); at least 3.6-fold (0.56 log units) between middle value and limit.
By their numbers in this assay, from the lowest: compound 3; then compound 2; then compound 1. At a limit, above all of these: compound 4.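

In this assay, hydrogen in place of bromo on this aromatic carbon gives an at least 3.8-fold higher number from compound 1 to compound 4 (0.58 log units; beyond the scatter). Among the compounds shown here, this is the first single-place comparison here, and it shows that with the rest of compound 1 unchanged, losing bromo weakens inhibition beyond the scatter. Compound 4 reads > 200000 nM, which is a limit of the assay and not a number: the limit of > 200000 nM in this assay, at which 1 of the 4 values shown sits.

From the compounds shown here alone, whether another group on this carbon, such as chloro, methoxy or an amine, would match or better bromo stays open. So does whether the step would hold on a core carrying a different side chain.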